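A few compounds are considered here, and "the series" means these few. Any claim that something is new, unique, unknown or untested is made for them only; others in the source may bear on it.

Half-lives measured so far in an ADME assay on a cell-free system (plasma, Homo sapiens) for metabolic stability, tested at 1 uM (on this read-out lower numbers stand for a shorter-lived compound and higher numbers for a longer-lived compound), are as follows.

Compound 1 (`C=CC(=O)N[C@H]1CCCN(S(=O)(=O)c2ccc(NC(=O)OCc3ccccc3)cc2)C1`) gives > 6 h
Compound 2 (`C=CC(=O)NC1CCN(S(=O)(=O)c2ccc(C(=O)NCCCc3ccccc3)cc2)CC1`) gives > 6 h
Compound 3 (`C=CC(=O)NC1CCN(S(=O)(=O)c2ccc(C(=O)N(C)Cc3ccccc3)cc2)CC1`) gives > 6 h

Each of these entries is a limit of the assay and not a number. Compound 2 is therefore known only by its limit (> 6 h) and has no exact place in the series. The whole picture amounts to the limit of > 6 h in this assay, at which 3 of the 3 values shown sit, and nothing finer.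

Compound 4 (`C=CC(=O)NC1CCN(S(=O)(=O)c2ccc(C(=O)NCc3cccc4ccccc34)cc2)CC1`) has not yet been measured. Its difference from compound 2 is naphthalen-1-yl in place of phenethyl on a saturated chain carbon bound to an amide-type nitrogen and amounts to naphthalen-1-yl in place of phenethyl on a saturated chain carbon bound to an amide-type nitrogen. Among the measured compounds shown here, the one measured step that bears on this change is a step that the two limits leave unreadable from compound 2 to compound 3 and it gives no usable size. No step beyond the scatter is therefore expected in this assay and no direction can be argued. The estimate amounts to a step that the limit leaves unreadable from compound 2 to compound 4 as the expected step. Compound 4 is expected at 8 h with an estimated range from 4 h to 20 h.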

Compound 4, half-life: > 6 h
Compound 4: a limit, no number; the forecaster's own chance of this, stated with the estimate: 80%; the middle value does not contradict the limit.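

Compound 4 gives > 6 h, which is a limit and not a number; compound 2 also stands only at a limit, so no step can be read between them. The compounds shown leave open how the actual half-lives of compound 1, compound 2, compound 3 and compound 4 compare, as the series offers only this: the limit of > 6 h in this assay, at which 4 of the 4 values shown sit.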